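Working notes: three measured compounds and one expected value

This account rests on a few compounds, and the source may have more. Where it says the series, first, only, none or still open, it means among the compounds named here.

In a functional assay on HepG2 cells (Homo sapiens) for cytotoxicity, read by MTT assay, with a stated time of 72 h (a higher number here means a weaker inhibitor, a lower number a stronger inhibitor), compound 1 `Cc1cc(=O)n(-c2cccc(F)c2)nc1C(=O)Nc1ccc(Oc2ncnc3[nH]ccc23)c(F)c1` gives 23100 nM, compound 2 `Cc1cc(=O)n(-c2ccc(Br)cc2F)nc1C(=O)Nc1ccc(Oc2ncnc3[nH]ccc23)c(F)c1` gives 32000 nM and compound 3 `Cc1cc(=O)n(-c2ccc(Br)cc2F)nc1C(=O)Nc1ccc(Oc2ncnc3c2ccn3C)cc1` gives 33600 nM; all three numbers lie within the scatter of one another, so no order among them is claimed. Compound 2 and compound 1 differ by 3-fluorophenyl in place of 4-bromo-2-fluorophenyl on an aromatic nitrogen and the step of a 1.4-fold lower number from compound 2 to compound 1 (0.14 log units; within the scatter) is small. The difference between the cores of compound 2 and compound 3 is not broken down here. Compound 4 `Cc1cc(=O)n(-c2cccc(F)c2)nc1C(=O)Nc1ccc(Oc2ncnc3c2ccn3C)cc1` has not been measured; it differs from compound 3 by 3-fluorophenyl in place of 4-bromo-2-fluorophenyl on an aromatic nitrogen, the same change at the same place as between compound 2 and compound 1. Because the earlier step of a 1.4-fold lower number from compound 2 to compound 1 (0.14 log units; within the scatter) stays within the scatter, the expected step is a 1.3-fold lower number from compound 3 to compound 4 (0.13 log units; within the scatter), a number of similar size. Compound 4 is estimated at 25000 nM in this assay, expected to fall between 10000 nM and 60000 nM.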

Compound 4, half-maximal inhibitory concentration: > 60000 nM
Compound 4: no number, only a limit; the forecaster's own chance of this, stated with the estimate: 15%; middle value at least 2.4-fold (0.38 log units) from the limit.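

In this assay compound 4 gives > 60000 nM, which is a limit of the assay and not a number. Replacing 4-bromo-2-fluorophenyl with 3-fluorophenyl on the core of compound 3 gives an at least 1.7-fold higher number from compound 3 to compound 4 (0.25 log units; that floor lies within the scatter), so only a floor is known for this step, not its size. The data neither show that the change carries over between the two cores nor show that it fails to: the same change on two cores in this assay, a 1.4-fold lower number (0.14 log units; within the scatter) from compound 2 to compound 1 and an at least 1.7-fold higher number (0.25 log units; that floor lies within the scatter) from compound 3 to compound 4; the limit leaves it open whether they differ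

The compounds shown leave open how large the step on the core of compound 3 really is. They also leave open how either core behaves in this assay with an amine or a carboxylic acid on the phenyl ring in place of the halogens.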